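Replacing Dichlorophenyl with Methoxyphenyl on the Carbonyl Carbon

The compounds below may be only part of what the source reports. "The series", "measured", "known", "first", "only" and "open" are said of these compounds alone.

Compound 1 `COc1cc(-c2cc(/C=C/C(=O)c3ccc(N)cc3)[nH]n2)cc(OC)c1OC`: -93%
Compound 2 `COc1ccc(-c2cc(/C=C/C(=O)c3ccc(OC)c(OC)c3)[nH]n2)cc1`: -96%
Compound 3 `COc1cc(-c2cc(/C=C/C(=O)c3ccc(Cl)c(Cl)c3)[nH]n2)cc(OC)c1OC`: -30%

In a functional assay on OVCAR-3 cells (Homo sapiens) for cytotoxicity, read by sulforhodamine B assay, with a stated time of 48 h, tested at 100 uM (on this read-out lower numbers stand for a stronger effect and higher numbers for a weaker effect at the one concentration tested), compound 3 gives -30%, the highest of the three numbers, far from compound 1 and compound 2. Compound 4 `COc1ccc(C(=O)/C=C/c2cc(-c3cc(OC)c(OC)c(OC)c3)n[nH]2)cc1` differs from compound 3 by 4-methoxyphenyl in place of 3,4-dichlorophenyl on a carbonyl carbon. Within the data shown here, the one step that bears on this change is a number 63 percentage points higher from compound 1 to compound 3 (beyond the scatter), which shows that the 3,4-dichlorophenyl group goes with a weak effect; compound 2, carrying a methoxy-bearing aryl on the carbonyl carbon, gives -96%. Removing the 3,4-dichlorophenyl group is therefore expected to lower the number strongly, by a number 55 percentage points lower from compound 3 to compound 4 (beyond the scatter). Compound 4 is estimated at -85%, within -100% to -55%.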

Compound 4, a percentage reported as activity, at one concentration (the size of the read-out at that concentration, not a potency): -69%
Compound 4: the middle estimate sits 16 percentage points below what was measured, within the range that was stated.
By their numbers in this assay, from the lowest: compounds 2 and 1 (each within the scatter of the next); then compound 4; then compound 3.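

In this assay, the 4-methoxyphenyl group on the carbonyl carbon recovers much of what is lost with the 3,4-dichlorophenyl group (a number 39 percentage points lower from compound 3 to compound 4 (beyond the scatter)), yet it does not match the 4-aminophenyl group (a number 24 percentage points higher from compound 1 to compound 4 (beyond the scatter)). On this core, the position therefore separates all three aryl groups, with the 4-aminophenyl group giving the lowest number. No available evidence explains this order. Going by these compounds, whether a 4-hydroxyphenyl or 4-(dimethylamino)phenyl group at this position would track the 4-aminophenyl or the 4-methoxyphenyl group remains open.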